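Compound 2 to compound 4: one aromatic group exchanged

The compounds below may be only part of what the source reports. "The series", "measured", "known", "first", "only" and "open" are said of these compounds alone.

Values in a physicochemical assay for solubility, in phosphate buffer, with a stated time of 18 h, at pH 7; a higher number here means a more soluble compound, a lower number a less soluble compound:
- Compound 1 `CC(C)CN1C(=O)c2ccccc2[C@H](C(=O)Nc2ccc(F)c(C#N)c2)[C@H]1c1ccco1`: 13000 nM
- Compound 2 `CC(C)CN1C(=O)c2ccccc2[C@H](C(=O)Nc2ccc(F)c(C#N)c2)[C@H]1c1ccc(C(N)=O)s1`: 19000 nM
- Compound 3 `CC(C)CN1C(=O)c2ccccc2[C@H](C(=O)Nc2ccc(F)c(C#N)c2)[C@H]1c1ccncc1`: 55000 nM

In this assay compound 2 gives 19000 nM, level with compound 1 within the scatter and beneath compound 3. Compound 4 `CC(C)CN1C(=O)c2ccccc2[C@H](C(=O)Nc2ccc(F)c(C#N)c2)[C@H]1c1cn[nH]c1` carries 1H-pyrazol-4-yl in place of 5-carbamoylthiophen-2-yl on a saturated ring carbon. Three measured exchanges at that carbon bear on it: a 1.5-fold higher number from compound 1 to compound 2 (0.16 log units; within the scatter), a 4.2-fold higher number from compound 1 to compound 3 (0.63 log units; beyond the scatter) and a 2.9-fold higher number from compound 2 to compound 3 (0.46 log units; beyond the scatter). Within the data shown here, none exceeded a modest size, and no compound with this new group has been measured. The expected step in this assay is small and upward, a 1.6-fold higher number from compound 2 to compound 4 (0.20 log units; within the scatter). Compound 4 is estimated at 30000 nM, with an expected range of 12000 nM to 80000 nM.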

Compound 4, solubility: 57000 nM
For compound 4 the middle estimate is 1.9-fold (0.28 log units) below the measured one, within the range that was stated.
By their numbers in this assay, from the lowest: compounds 1 and 2 (each within the scatter of the next); then compounds 3 and 4 (each within the scatter of the next).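

In this assay, 1H-pyrazol-4-yl on the saturated ring carbon gives a 3.0-fold higher number from compound 2 to compound 4 (0.48 log units; beyond the scatter) and a 4.4-fold higher number from compound 1 to compound 4 (0.64 log units; beyond the scatter), both beyond the scatter, while a 1.0-fold higher number from compound 3 to compound 4 (0.02 log units; within the scatter) stays within it. A five-membered aromatic ring at this carbon can therefore stand level with the pyridin-4-yl of compound 3, although compound 1 and compound 2, which also carry such a ring, lie lower. No evidence on the cause of these steps is at hand. Open, going by these compounds, is how a methyl group on the pyrazole nitrogen, or an amine on the pyrazole ring, would compare with compound 4.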